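The source may hold more compounds than are shown below. What is called first, only, known or untested is meant among the compounds shown, and "the series" means these compounds.

Working notes on the series.

Compound 1 `CCCc1cnc2c(C#N)c(N3CCN(c4ncccn4)CC3)ccn12` is assessed in a functional assay on CHO cells with metabotropic glutamate receptor 2 (Homo sapiens) as the target, read by GTPgammaS binding; a lower number here means that less compound is needed, a higher number that more compound is needed for the effect. In this assay compound 1 gives > 3160 nM, which is a limit of the assay and not a number (the limit of > 3160 nM in this assay, at which 1 of the 3 values shown sits). Among the compounds with values here, compound 2 `CCCc1cnc2c(C#N)c(N3CCN(c4nc(C)cc(C)n4)CC3)ccn12` gives 646 nM in this assay; the step of an at least 4.8-fold lower number from compound 1 to compound 2 (0.68 log units; beyond the scatter) is the one measured step that changes a single place. Within the data shown here, compound 3 `N#Cc1c(-c2ccc(N3CCCCC3)cc2)ccn2c(CC(F)(F)F)cnc12` gives 234 nM in this assay; it differs from compound 1 in more than one place, so no step is counted between them.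

Compound 4 `CCc1cnc2c(C#N)c(N3CCN(c4ncccn4)CC3)ccn12` is not yet measured. It differs from compound 1 by hydrogen in place of methyl on a saturated chain carbon, two bonds along the chain from an aromatic carbon. Among the measured compounds shown here, none of the measured steps alters this chain, so no measured step bears directly on it. Compound 1 sits at the limit of this assay, and the change to compound 4 is small, so compound 4 is expected to remain near that limit. The step that the limit leaves unreadable from compound 1 to compound 4 is estimated as no change beyond the scatter. For compound 4 the estimate in this assay is 5000 nM, with a range from 1500 nM to 20000 nM.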

Compound 4, half-maximal effective concentration: > 3160 nM
Compound 4: no number, only a limit; the forecaster's own chance of this, stated with the estimate: 60%; the middle value does not contradict the limit.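

In this assay compound 4 gives > 3160 nM, a limit of the assay and not a number; compound 1 also sits at a limit, so no step can be read between compound 1 and compound 4: the limit of > 3160 nM in this assay, at which 2 of the 4 values shown sit.

On these data alone, whether propyl to ethyl alters the value in a compound with a readable number stays open.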